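A Second Methoxy on the Lactam Core

This account rests on a few compounds, and the source may have more. Where it says the series, first, only, none or still open, it means among the compounds named here.

Measured in a functional assay on HT-29 cells (Homo sapiens) for inhibition, read by sulforhodamine B assay, with a stated time of 48 h; on this read-out lower numbers stand for stronger inhibition of growth and higher numbers for weaker inhibition of growth:
Compound 1 `O=c1ccoc(/C=C/c2ccccc2)c1`: 344 uM
Compound 2 `COc1ccc(/C=C/c2cc(=O)cco2)cc1`: 379 uM
Compound 3 `COc1ccc(/C=C/C2CC=CC(=O)N2)cc1`: > 1090 uM

For compound 3 the value is a limit of the assay, not a number. The change from compound 1 to compound 2 is methoxy in place of hydrogen on an aromatic carbon; it gave a 1.1-fold higher number from compound 1 to compound 2 (0.04 log units; within the scatter). How the core of compound 3 differs from the core of compound 1 is not broken down here.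

Compound 4 `COc1ccc(/C=C/C2CC=CC(=O)N2)c(OC)c1` has not yet been measured. It differs from compound 3 by methoxy in place of hydrogen on an aromatic carbon. The surroundings are not the same as before: in the earlier case the methoxy entered para to a group of 9 heavy atoms, here it enters ortho to a group of 9 heavy atoms and meta to a methoxy group, so this is the same kind of change, not the same.

In this assay the step that the limit leaves unreadable from compound 3 to compound 4 is expected to be small, like the earlier 1.1-fold higher number from compound 1 to compound 2 (0.04 log units; within the scatter), and the expectation rests on compound 3 already sitting at the limit of > 1090 uM in this assay, at which 1 of the 3 values shown sits. Compound 4 is therefore estimated at 1500 uM, between 700 uM and 4000 uM, most probably reported again only as a limit.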

Compound 4, concentration for growth inhibition (reported as GI): > 964 uM
Compound 4 gave a limit, no number (the forecaster's own chance of this, stated with the estimate: 75%); the middle value is on the limit's open side.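

Among these compounds, compound 3 and compound 4 each gave only a limit of the assay rather than a number, so no step between them can be read. The compounds shown leave open whether methoxy in place of hydrogen on an aromatic carbon changes growth inhibition at all on the core of compound 3.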